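Compound 3: A Large Group Enters the Shared Core

This account rests on a few compounds, and the source may have more. Where it says the series, first, only, none or still open, it means among the compounds named here.

- Compound 1 `Cc1ccccc1C(=O)Nc1cc(Cl)ccn1` gives 224000 nM as measured
- Compound 2 `Cc1ccnc(NC(=O)c2ccccc2C)c1` gives 146000 nM as measured

Both compounds were tested in an ADME assay on L6 cells (Rattus norvegicus) for cytotoxicity, read by resazurin assay, with a stated time of 70 h (a higher number here means a weaker inhibitor, a lower number a stronger inhibitor), and the difference between them is small (a 1.5-fold lower number from compound 1 to compound 2 (0.19 log units; within the scatter)). Compound 2 therefore stands level with compound 1, and neither can be ranked above the other.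

The next compound, compound 3 (`Cc1ccccc1C(=O)Nc1cc(C#Cc2ccccc2)ccn1`), differs from compound 2 in one place on the shared core. It carries 2-phenylethynyl in place of methyl on an aromatic carbon, opposite the ring nitrogen (2-phenylethynyl in place of methyl on an aromatic carbon).

Going by the values given here, only one measured step bears on this change, and it bears weakly. It exchanged chloro and methyl, whereas a far larger group enters here, so the data do not settle the direction. Compound 2, at 146000 nM, has much more room to fall than to rise, so a lower number in this assay is expected, with wide uncertainty. The expected step is a clear one (a 3.7-fold lower number from compound 2 to compound 3 (0.56 log units; beyond the scatter)). For compound 3 the estimated value is 40000 nM (expected range 8000 nM to 150000 nM).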

Compound 3, half-maximal inhibitory concentration in the L6 assay: 198000 nM
For compound 3 the middle estimate is 5.0-fold (0.69 log units) below the measured one; measured number above the stated range.
By their numbers in the L6 assay, from the lowest: compounds 2, 3 and 1 (each within the scatter of the next).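

At this position, opposite the ring nitrogen, the large 2-phenylethynyl group leaves the picture in the L6 assay the same as the much smaller methyl and chloro, since both steps stay within the scatter (a 1.4-fold higher number from compound 2 to compound 3 (0.13 log units; within the scatter); a 1.1-fold lower number from compound 1 to compound 3 (0.05 log units; within the scatter)). The same exchange of methyl for 2-phenylethynyl does register clearly in a physicochemical assay for solubility, read by nephelometry, measured as kinetic solubility, at pH 6.5, tested at 10 mg/mL; on this read-out higher numbers stand for higher solubility and lower numbers for lower solubility (an at least 15-fold lower number from compound 2 to compound 3 (1.19 log units; beyond the scatter)), and this is a measured loss of solubility: the measured solubility of compound 2, 25 ug/mL, and of compound 3, < 1.6 ug/mL, an at least 15-fold lower number (1.19 log units; beyond the scatter). In the physicochemical assay compound 2 gives 25 ug/mL. In the physicochemical assay compound 3 gives < 1.6 ug/mL, which is a limit of the assay and not a number.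

The compounds shown leave open whether a group of similar length ending in an amine or a carboxylic acid at this position would leave the picture in the L6 assay unchanged while giving a higher number in the physicochemical assay. They also cannot tell how much of compound 3 stayed dissolved during the L6 assay, so what its reading there says about toxicity to the cells remains uncertain.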